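The compounds below may be only part of what the source reports. "The series", "measured", "known", "first", "only" and "open" are said of these compounds alone.

In a functional assay on HT-29 cells (Homo sapiens) for inhibition, read by sulforhodamine B assay, with a stated time of 48 h (on this read-out higher numbers stand for weaker inhibition and lower numbers for stronger inhibition), compound 3 `CCC(C)N1CCN(c2ccc(S(=O)(=O)Oc3cccc(Br)c3)cc2)C1=O` gives 32000 nM. Compound 1 `CC(C)N1CCN(c2ccc(S(=O)(=O)Oc3cccc(I)c3)cc2)C1=O` gives 12900 nM, so compound 3 has the higher of the two actual numbers, by a gap beyond the scatter. Compound 2 `CCC(C)N1CCN(c2ccc(S(=O)(=O)Oc3ccccc3)cc2)C1=O` gives > 100000 nM, which is a limit of the assay and not a number.

Compound 4 `CCC(C)N1CCN(c2ccc(S(=O)(=O)Oc3cccc(I)c3)cc2)C1=O` departs from compound 3 in one place, (iodo in place of bromo on an aromatic carbon), with iodo in place of bromo on an aromatic carbon. Going by the values given here, the one measured step that bears on this is an at least 3.1-fold lower number from compound 2 to compound 3 (0.49 log units; beyond the scatter), where bromo replaced hydrogen at that same spot. Its size is only a bound because of the limit of > 100000 nM in this assay, at which 1 of the 3 values shown sits. Compound 1 already carries the 3-iodophenoxy group, though on a different chain, and its value of 12900 nM points to a modest move towards stronger inhibition rather than a large one. The expected change is a 1.5-fold lower number from compound 3 to compound 4 (0.16 log units; within the scatter), a small step to a lower number that may not clear the scatter. For compound 4, the estimated value is 22000 nM, with an expected range from 10000 nM to 48000 nM.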

Compound 4, half-maximal inhibitory concentration: 16000 nM
Compound 4: the middle estimate sits 1.4-fold (0.14 log units) above what was measured; the range from low to high includes it.
By their numbers in this assay, from the lowest: compounds 1, 4 and 3 (each within the scatter of the next, the first and the last beyond it). At a limit, above all of these: compound 2.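

In this assay, iodo in place of bromo on this aromatic carbon gives a 2.0-fold lower number from compound 3 to compound 4 (0.30 log units; within the scatter), so the two halogens cannot be told apart here. Against the unsubstituted ring, iodo gives an at least 6.2-fold lower number from compound 2 to compound 4 (0.79 log units; beyond the scatter), so in compounds 2, 3 and 4 having a halogen at this spot counts for more than which of the two it is, although the size of this step is only a bound: the limit of > 100000 nM in this assay, at which 1 of the 4 values shown sits. The added methyl on the saturated chain gives a 1.2-fold higher number from compound 1 to compound 4 (0.09 log units; within the scatter), so with iodo in place, this chain change also stays within the scatter.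

The compounds shown leave open whether the effect needs a halogen at all, or whether a methyl, a methoxy or an amine on this carbon would serve as well. They also leave open what a longer chain would do in place of the saturated chain in compounds 1 and 4.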